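Taking the nitro group off compound 3

The compounds below may be only part of what the source reports. "The series", "measured", "known", "first", "only" and "open" are said of these compounds alone.

Compound 1 `COc1ccc(/C=C2\Cc3c(cc(OC)c(OC)c3OC)C2=O)cc1` gives 560 nM
Compound 2 `COc1ccc(/C=C2\Cc3cc(OC)c(OC)c(OC)c3C2=O)cc1O` gives > 10000 nM as a limit
Compound 3 `COc1ccc(/C=C2\Cc3cc(OC)c(OC)c(OC)c3C2=O)cc1[N+](=O)[O-]` gives > 10000 nM as a limit

In a functional assay on Bel-7402 cells (Homo sapiens) for antiproliferative activity, read by MTT assay, with a stated time of 48 h (on this read-out lower numbers stand for stronger inhibition of growth and higher numbers for weaker inhibition of growth), compound 3 gives > 10000 nM as a limit, not as a number. Compound 2 gives > 10000 nM as a limit too. The main fact so far is therefore the limit of > 10000 nM in this assay, at which 2 of the 3 values shown sit, and only compound 1 has a true number, 560 nM in this assay.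

Compound 4 `COc1ccc(/C=C2\Cc3cc(OC)c(OC)c(OC)c3C2=O)cc1` differs from compound 3 at one place only, (hydrogen in place of nitro on an aromatic carbon), with hydrogen in place of nitro on an aromatic carbon, ortho to a methoxy group. Within the data shown here, the one measured step at this place, a step that the two limits leave unreadable from compound 2 to compound 3, puts nitro in place of hydroxy and has no readable size. Both groups tried here end at the limit, and hydrogen has not yet been tried. The expectation therefore starts from compound 3 at > 10000 nM as a limit. Compound 1 at 560 nM shows that a true number can be reached in this assay, so the expected range stays wide toward stronger inhibition.

The estimated change is a number no higher from compound 3 to compound 4 (the limit leaves the size open), and no clear gain in growth inhibition is expected. Compound 4 is estimated at 10000 nM, with an expected range from 3000 nM to 30000 nM, and it may well report only a limit.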

Compound 4, concentration for 50% growth inhibition: > 10000 nM
Compound 4: a limit, no number; the forecaster's own chance of this, stated with the estimate: 65%; the middle value sits exactly at the limit.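

No step can be read among compound 2, compound 3 and compound 4, since in this assay each gives only a limit and not a number: the limit of > 10000 nM in this assay, at which 3 of the 4 values shown sit.

The compounds shown leave open how strongly compound 2, compound 3 and compound 4 inhibit growth, and whether hydroxy, nitro and hydrogen differ at this place at all.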